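The source may hold more compounds than are shown below. What is called first, only, known or untested is meant among the compounds shown, and "the series" means these compounds.

Compound 1 `O=C1NCCN1c1ccc(S(=O)(=O)Nc2ccccc2)cc1` is the parent of this small set. Going by the values given here, in a functional assay on M21 cells (Homo sapiens) for antiproliferative activity, read by sulforhodamine B assay, with a stated time of 48 h (on this read-out lower numbers stand for stronger inhibition and higher numbers for weaker inhibition), compound 1 gives 200 nM, the lower of the two numbers measured so far. Compound 2 `CCCCOc1ccc(NS(=O)(=O)c2ccc(N3CCNC3=O)cc2)cc1` carries a butoxy group on the ring at the far end, and in this assay compound 2 gives 580 nM. Compound 3 `CC(C)Cc1ccc(NS(=O)(=O)c2ccc(N3CCNC3=O)cc2)cc1` carries an isobutyl group instead. For compound 3 this assay reports only a limit, > 1000 nM, which is the limit of > 1000 nM in this assay, at which 1 of the 3 values shown sits. Both additions weakened the effect: a 2.9-fold higher number from compound 1 to compound 2 (0.46 log units; beyond the scatter) and an at least 5.0-fold higher number from compound 1 to compound 3 (0.69 log units; beyond the scatter), while an at least 1.7-fold higher number from compound 2 to compound 3 (0.23 log units; that floor lies within the scatter).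

Compound 4 `COc1ccccc1NS(=O)(=O)c1ccc(N2CCNC2=O)cc1` differs from compound 1 in one place: methoxy in place of hydrogen on an aromatic carbon. The methoxy group is smaller than the butoxy or isobutyl group, and it sits ortho to a large group rather than where those groups sat, so the two earlier steps bear on it only loosely. Since both steps raised the number, a modest rise is expected here too, roughly a 1.8-fold higher number from compound 1 to compound 4 (0.24 log units; within the scatter). Compound 4 is therefore estimated at 350 nM, with a likely range from 150 nM to 900 nM.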

Compound 4, half-maximal inhibitory concentration: 300 nM
Compound 4: middle estimate off by 1.2-fold (0.07 log units), on the high side; the range from low to high includes it.
By their numbers in this assay, from the lowest: compounds 1, 4 and 2 (each within the scatter of the next, the first and the last beyond it). At a limit, above all of these: compound 3.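

Going from phenyl to 2-methoxyphenyl, this assay shows a 1.5-fold higher number from compound 1 to compound 4 (0.18 log units; within the scatter), so compound 1 and compound 4 cannot be told apart. Going by these compounds alone, the earlier steps from compound 1, to butoxy in compound 2 and to isobutyl in compound 3, both lie beyond the scatter, whereas methoxy on this aromatic carbon, ortho to a large group, is the first added group whose step does not; since methoxy differs from those groups in both size and place, the two differences cannot be separated. Nothing measured here explains why this step stays within the scatter.

Still open, as far as these compounds go, is whether butoxy at this same place would read like methoxy, and whether methoxy on another carbon of the ring would read the same. Also open, from the compounds shown here alone, is how a hydroxyl group, an amine or a carboxylic acid would fare here.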